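Pyrazole to pyridine on the amide nitrogen

The source may hold more compounds than are shown below. What is called first, only, known or untested is meant among the compounds shown, and "the series" means these compounds.

Of the compounds shown here, three have been measured in an assay on HEK293 cells for agonist activity at transient receptor potential cation channel subfamily M member 8 (Homo sapiens), read by fluorescence and calcium flux, with a stated time of 15 min; on this read-out higher numbers stand for an effect only at larger amounts of compound and lower numbers for an effect already at smaller amounts. Compound 1 `CCN(Cc1ccoc1)C(=O)COc1ccc(C)cc1` gives 136 nM, and compound 2 `CCN(Cc1cccs1)C(=O)COc1ccc(C(C)C)cc1` gives 397 nM. Compound 3 `Cc1ccc(OCC(=O)N(Cc2cccs2)c2c[nH]nc2C)cc1` stands apart with 0.4 nM, the lowest of the three numbers; the gap to compound 1 and the still wider gap to compound 2 both lie beyond the usual scatter, so compound 3 is the most potent compound in this set.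

Compound 4 `Cc1ccc(OCC(=O)N(Cc2cccs2)c2cccnc2)cc1` has not yet been measured. It differs from compound 3 in one place: pyridin-3-yl in place of 3-methyl-1H-pyrazol-4-yl on an amide-type nitrogen. The group that leaves carries one hydrogen-bond donor and one acceptor, while the group that enters keeps one acceptor and has no donor. For the measured compounds named here, no measured pair shows the effect of this exchange, since compound 1 and compound 2 carry different substituents on that nitrogen and differ from compound 3 elsewhere as well.

Because compound 3 gives 0.4 nM, far apart from the other two, the step from compound 3 to compound 4 is expected to move upward, beyond the scatter, by about a 25-fold higher number from compound 3 to compound 4 (1.40 log units; beyond the scatter). Compound 4 is therefore estimated at 10 nM, with a range from 1 nM to 100 nM.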

Compound 4, half-maximal effective concentration: 198 nM
Compound 4: the middle estimate sits 20-fold (1.30 log units) below what was measured, outside the stated range (above it).
By their numbers in this assay, from the lowest: compound 3; then compounds 1, 4 and 2 (each within the scatter of the next, the first and the last beyond it).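

In this assay, for the compounds shown here, replacing 3-methyl-1H-pyrazol-4-yl with pyridin-3-yl on the amide-type nitrogen, with the rest of the structure unchanged, gives a 500-fold higher number from compound 3 to compound 4 (2.69 log units; beyond the scatter), the first direct reading of this position and a large step beyond the scatter. The exchange keeps the heavy-atom count of the group and its one hydrogen-bond acceptor, so the step cannot be tied to either of these counts; it comes with the loss of the hydrogen-bond donor, the methyl group and the five-membered ring, and with one ring nitrogen in place of two. No independent measurement here bears on the origin of this step.

The compounds shown leave open which of these differences carries the step, since all of them change together in this single exchange. An unsubstituted 1H-pyrazol-4-yl, a 1,3-dimethylpyrazol-4-yl or a pyridin-4-yl on the same nitrogen would separate the methyl group, the hydrogen-bond donor and the place of the ring nitrogen from one another.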